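The compounds below may be only part of what the source reports. "The series", "measured", "known", "first", "only" and "open" are said of these compounds alone.

Measured compounds and their half-lives:

compound 1 `CC(C)(C)C1=C(C(=O)O)N2C(=O)[C@H](CO)[C@H]2O1` — 5 h
compound 2 `CC(C)(C)C1=C(C(=O)O)N2C(=O)[C@H]([C@@H](O)c3ccncc3)[C@H]2O1` — 6 h

In an ADME assay, in phosphate buffer, at 28 degrees C, at pH 7.0 (on this read-out lower numbers stand for a shorter-lived compound and higher numbers for a longer-lived compound), compound 1 gives 5 h and compound 2 gives 6 h. Among the measured compounds shown here, the single measured step, a 1.2-fold higher number from compound 1 to compound 2 (0.08 log units; within the scatter), is within the scatter, so compound 1 and compound 2 cannot be told apart on this read-out.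

Compound 3 `CC(C)(C)C1=C(C(=O)O)N2C(=O)[C@H](CNS(C)(=O)=O)[C@H]2O1` differs from compound 1 by methanesulfonamido in place of hydroxy on a saturated chain carbon bound to a saturated ring carbon. For the measured compounds named here, no measured step tests this exchange: the only step available swaps a hydrogen for a pyridin-4-yl at a different place and changes the half-life by an amount inside the scatter. Nothing in the measured compounds therefore points to a shift beyond the scatter for the step from compound 1 to compound 3.

The half-life of compound 3 in this assay is estimated at 5 h, in the range 2.5 h to 10 h. This estimate means a step of no change at the digits printed from compound 1 to compound 3 (within the scatter), expected to stay within the scatter.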

Compound 3, half-life: 2.2 h
Estimate against measurement, compound 3: 2.3-fold (0.36 log units) above, outside the stated range (below it).
By their numbers in this assay, from the lowest: compound 3; then compounds 1 and 2 (each within the scatter of the next).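

In this assay, the saturated chain carbon bound to a saturated ring carbon responds to a change in the group it carries: methanesulfonamido in place of hydroxy gives a modest shift (a 2.3-fold lower number from compound 1 to compound 3 (0.36 log units; beyond the scatter)) that lies beyond the scatter. The earlier step (a 1.2-fold higher number from compound 1 to compound 2 (0.08 log units; within the scatter)) stayed within the scatter and involved a different change, so it gave no sign that this exchange would shorten the half-life. No available evidence bears on why the half-life shifts with this exchange.

The compounds shown leave open whether the shift follows the nitrogen that enters or the methanesulfonyl part attached to it. A plain amine or an acetamido group on the same chain carbon would help to separate the two.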